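This account rests on a few compounds, and the source may have more. Where it says the series, first, only, none or still open, it means among the compounds named here.

Measured so far in a functional assay on Jurkat cells (Homo sapiens) for antiproliferative activity, read by MTT assay, with a stated time of 48 h; a lower number here means a stronger inhibitor, a higher number a weaker inhibitor
Compound 1 `CCOC(=O)/C=C/c1ccc2c(c1)C(=O)C(=O)N2Cc1ccc(Br)cc1` gives 70 nM
Compound 2 `CCCCOC(=O)/C=C/c1ccc2c(c1)C(=O)C(=O)N2Cc1ccc(OC)cc1` gives 220 nM

Of these two, compound 2 has the higher number (220 nM), and its gap to compound 1 lies beyond the scatter. Compound 3 `CCCCOC(=O)/C=C/c1ccc2c(c1)C(=O)C(=O)N2Cc1ccc(Br)cc1` has not yet been measured. It departs from compound 2 by a single change (bromo in place of methoxy on an aromatic carbon), with bromo in place of methoxy on an aromatic carbon. Among the measured compounds shown here, no measured pair isolates this change, so any expectation is loose. The 4-bromobenzyl group of compound 3 also occurs in compound 1 (70 nM), which points to a moderate fall in the number in this assay rather than no change. The expected size of this move (a 2.2-fold lower number from compound 2 to compound 3 (0.34 log units; beyond the scatter)) is only an estimate. For compound 3 the estimated value is 100 nM (expected range 40 nM to 230 nM).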

Compound 3, half-maximal inhibitory concentration: 700 nM
For compound 3 the middle estimate is 7.0-fold (0.85 log units) below the measured one; the measured number lies above the stated range.
By their numbers in this assay, from the lowest: compound 1; then compound 2; then compound 3.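

In this assay, bromo in place of methoxy on an aromatic carbon, para to a large group, gives a 3.2-fold higher number from compound 2 to compound 3 (0.50 log units; beyond the scatter) and so raises the number on this ester chain, which shows that the 4-bromobenzyl group does not carry a low number by itself. With the 4-bromobenzyl group held fixed, ethyl in place of hydrogen on a saturated chain carbon gives a 10-fold higher number from compound 1 to compound 3 (1.00 log units; beyond the scatter) and so also raises the number, which shows that the outcome at this benzyl position cannot be read apart from the ester chain. Nothing measured here gives a cause for either step.

From the compounds shown here alone, whether methoxy would also give a lower number than bromo on the shorter ester chain of compound 1 stays open. So does the place of a 4-chlorobenzyl group, a 4-aminobenzyl group, or a longer ester chain such as hexyl.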